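From Chloro to Ethyl on the Shared Core

A few compounds are considered here, and "the series" means these few. Any claim that something is new, unique, unknown or untested is made for them only; others in the source may bear on it.

Of the compounds shown here, three have so far been measured in an assay on IMR-32 cells for displacement of a labelled ligand from corticotropin-releasing factor receptor 1 (Homo sapiens), read by scintillation counting, with a stated time of 2 h; a lower number here means a stronger inhibitor, a higher number a weaker inhibitor. Compound 1 `CCc1nc(NC(CC)CC)c(Cl)nc1-c1ccc(Cl)cc1Cl` gives 71 nM in this assay. Compound 2 `CCOc1ccc(-c2nc(CC)c(NC(CC)CC)nc2CC)c(OC)c1` gives 7.8 nM, and compound 3 `CCC(CC)Nc1nc(C)c(-c2ccc(OC(F)F)cc2Cl)nc1OC` gives 4.6 nM. Among these three numbers compound 1 stands highest, so it is the weakest inhibitor of the set: its nearest neighbour is compound 2, whose number lies lower by a gap beyond the usual scatter, and compound 3 lies lower still, also beyond the scatter.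

Compound 4 `CCc1nc(-c2ccc(Cl)cc2Cl)c(CC)nc1NC(CC)CC` has not yet been measured. It differs from compound 1 in a single place: ethyl in place of chloro on an aromatic carbon. The change sits on an aromatic carbon of the six-membered aromatic ring with two nitrogen, next to the ring nitrogen and ortho to the (pentan-3-yl)amino group.

Among the measured compounds shown here, no pair of measured compounds shows this change on its own. Compound 2 does carry an ethyl group on its core and gives 7.8 nM, but its aryl part also differs, so that comparison is not clean. A modest downward step is expected, not a large one. Compound 4 is therefore estimated at 30 nM, with a range from 8 nM to 120 nM. This estimate means an expected step of a 2.4-fold lower number from compound 1 to compound 4 (0.37 log units; beyond the scatter).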

Compound 4, inhibition constant: 4.1 nM
For compound 4 the middle estimate is 7.3-fold (0.86 log units) above the measured one; the measured number lies below the stated range.
By their numbers in this assay, from the lowest: compounds 4, 3 and 2 (each within the scatter of the next); then compound 1.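

Ethyl in place of chloro on this aromatic carbon, ortho to the (pentan-3-yl)amino group, gives in this assay a 17-fold lower number from compound 1 to compound 4 (1.24 log units; beyond the scatter), and the step is large for a swap of one small group for another. Among the compounds shown here, this is the first clean reading of this position, as the rest of the two molecules is identical, including the aryl part, and no earlier pair of compounds differed in one place only. The result shows that the number in this assay responds strongly to what sits on this one carbon, but no separate measurement speaks to what lies behind the step.

Only chloro and ethyl can be compared directly at this place, so a longer chain such as propyl, or a different kind of group such as a nitrile or an amine, could tell whether the trend continues or reverses. Also open, on these data alone, is whether the same swap would give a step of similar size on a compound carrying a different aryl part, as a single pair cannot show how far it carries.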